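Swapping the outer ring from chloropyridine to methylpyrazole

The source may hold more compounds than are shown below. What is called first, only, known or untested is meant among the compounds shown, and "the series" means these compounds.

Compound 2 `O=C1C(=O)N(Cc2ccc(-c3ccc(Cl)nc3)cc2)c2ccc(OC(F)(F)F)cc21` carries a 6-chloropyridin-3-yl group on an aromatic carbon of a six-membered aromatic ring of carbon only, para to a large group. For the measured compounds named here, in a functional assay on CHO cells for agonist activity at muscarinic acetylcholine receptor M5 (Homo sapiens), read by calcium flux (on this read-out lower numbers stand for an effect already at smaller amounts and higher numbers for an effect only at larger amounts of compound), compound 2 gives 4800 nM, the higher end of the two numbers known, though the gap to its neighbour lies within the scatter. That neighbour is compound 1 `O=C1C(=O)N(Cc2ccc(-c3ccsc3)cc2)c2ccc(OC(F)(F)F)cc21`, which in this assay gives 2800 nM; the step of a 1.7-fold higher number from compound 1 to compound 2 (0.23 log units; within the scatter) shows that exchanging one small aromatic ring for another left the read-out essentially unchanged. Compound 3 `Cn1cc(-c2ccc(CN3C(=O)C(=O)c4cc(OC(F)(F)F)ccc43)cc2)cn1` repeats this kind of exchange: 1-methyl-1H-pyrazol-4-yl in place of 6-chloropyridin-3-yl on an aromatic carbon. Going by the values given here, because only the step of a 1.7-fold higher number from compound 1 to compound 2 (0.23 log units; within the scatter) bears on such a swap, and it stayed within the scatter, compound 3 is expected to move little, with a 1.2-fold lower number from compound 2 to compound 3 (0.08 log units; within the scatter) as the estimated step. For compound 3 in this assay the estimate is 4000 nM, with a range from 1500 nM to 12000 nM.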

Compound 3, half-maximal effective concentration: 3300 nM
Compound 3: the middle estimate sits 1.2-fold (0.08 log units) above what was measured; the range from low to high includes it.
By their numbers in this assay, from the lowest: compounds 1, 3 and 2 (each within the scatter of the next).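

At this place, para to a large group, a third kind of outer ring now joins the comparison in this assay. The 1-methyl-1H-pyrazol-4-yl group, a five-membered aromatic ring with 2 hetero atoms, stays within the scatter of both six-membered 6-chloropyridin-3-yl (a 1.5-fold lower number from compound 2 to compound 3 (0.16 log units; within the scatter)) and five-membered thiophen-3-yl (a 1.2-fold higher number from compound 1 to compound 3 (0.07 log units; within the scatter)), so neither ring size nor these changes of hetero atoms separate the three compounds on this read-out. Nothing measured here explains why the read-out stays this flat.

From the compounds shown here alone, all three groups are aromatic rings, so it stays open whether a morpholine, an amine or a carboxylic acid at this place would shift the number. Also open, going by these compounds, is whether replacing the trifluoromethoxy group on the shared core would move the read-out more than these ring swaps did.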